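A few compounds are considered here, and "the series" means these few. Any claim that something is new, unique, unknown or untested is made for them only; others in the source may bear on it.

Measured compounds:
Compound 1, `c1ccc2c(c1)CN[C@@H](CN(CCCCNC1CCOCC1)[C@H]1CCCc3cccnc31)C2`, which in a functional assay on cells for agonist activity at C-X-C chemokine receptor type 4 (Homo sapiens), read by fluorescence and calcium flux, with a stated time of 90 s (on this read-out higher numbers stand for an effect only at larger amounts of compound and lower numbers for an effect already at smaller amounts), gives a value of > 30000 nM; this is a limit of the assay, not a number.
Compound 2, `CC1(C)CCC(NCCCCN(C[C@H]2Cc3ccccc3CN2)[C@H]2CCCc3cccnc32)CC1`, which in this assay gives > 30000 nM, again a limit.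
Compound 3, `c1ccc2c(c1)CN[C@@H](CN(Cc1ccc(CNC3CCOCC3)cc1)[C@H]1CCCc3cccnc31)C2`, which in this assay gives > 30000 nM, also a limit.

The change from compound 1 to compound 2 is 4,4-dimethylcyclohexyl in place of oxan-4-yl on an amine nitrogen, and its step is a step that the two limits leave unreadable from compound 1 to compound 2. The difference between the core of compound 1 and the core of compound 3 is not broken down here. Compound 4, `CC1(C)CCC(NCc2ccc(CN(C[C@H]3Cc4ccccc4CN3)[C@H]3CCCc4cccnc43)cc2)CC1`, not yet measured, carries the same change relative to compound 3: 4,4-dimethylcyclohexyl in place of oxan-4-yl on an amine nitrogen, at the same place. Since (the limit of > 30000 nM in this assay, at which 3 of the 3 values shown sit), the step from compound 3 to compound 4 is expected to stay unreadable, a step that the limit leaves unreadable from compound 3 to compound 4. Compound 4 is therefore estimated at 45000 nM, most likely reported only as a limit.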

Compound 4, half-maximal effective concentration: > 30000 nM
Compound 4: no number, only a limit (the forecaster's own chance of this, stated with the estimate: 85%); the middle value lies beyond the limit too.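

In this assay compound 4 gives > 30000 nM, which is a limit, and its step from compound 3 cannot be read. The compounds shown leave open what size the exchange of oxan-4-yl for 4,4-dimethylcyclohexyl has, and whether either core gives a measurable value.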